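A few compounds are considered here, and "the series" means these few. Any claim that something is new, unique, unknown or untested is made for them only; others in the source may bear on it.

Compound 1 `O=C1CC(c2ccccc2)Cc2[nH]c(=O)c(C(=O)c3ccccc3)cc21` gives 0% in an assay on CHO cells for displacement of a labelled ligand from adenosine receptor A3 (Homo sapiens), tested at 10 uM; on this read-out lower numbers stand for less inhibition and higher numbers for more inhibition at the one concentration tested (going by the name of the read-out). Compound 2 `O=C1CCCc2[nH]c(=O)c(S(=O)(=O)c3ccccc3)cc21` gives 0% in this assay.

Compound 2 stands level with compound 1 at the digits shown; the two values lie within the scatter of each other, so nothing separates them. Compound 3 `O=C1CC(c2ccccc2)Cc2[nH]c(=O)c(S(=O)(=O)c3ccccc3)cc21` differs from compound 2 by one change: phenyl in place of hydrogen on a saturated ring carbon. With no difference to go on between the two measured compounds, no step beyond the scatter is expected for this change, and the expected step is a number 2 percentage points higher from compound 2 to compound 3 (within the scatter). In this assay compound 3 is therefore estimated at 2%, with a range from 0% to 15%.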

Compound 3, a percentage reported as inhibition, at one concentration (the size of the read-out at that concentration, not a potency): 18%
Compound 3: middle estimate off by 16 percentage points, on the low side, outside the stated range (above it).
By their numbers in this assay, from the lowest: compounds 1 and 2 (each within the scatter of the next); then compound 3.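

In this assay there is a number 18 percentage points higher from compound 2 to compound 3 (beyond the scatter) with phenyl in place of hydrogen on a saturated ring carbon, and a number 18 percentage points higher from compound 1 to compound 3 (beyond the scatter) with phenylsulfonyl in place of benzoyl on an aromatic carbon. For the compounds shown here, the read-out therefore rises only where phenyl and phenylsulfonyl occur together, a dependence that the two earlier compounds, each carrying only one of these groups, could not show. No measurement at hand explains this dependence.

Going by these compounds alone, it remains open whether a methyl or an amine on that saturated ring carbon would give a similar rise, and whether phenyl is the only group there that does so alongside phenylsulfonyl.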